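This account rests on a few compounds, and the source may have more. Where it says the series, first, only, none or still open, it means among the compounds named here.

Compound 1 `COc1ccc(/C=C/C(=O)c2ccc(OC)c3c2OC(C)(C)C=C3)cc1O`: 800 nM
Compound 2 `COc1ccc(/C=C/C(=O)c2ccc(OC)c3c2OC(C)(C)C=C3)cc1OCCCN(C)C`: 4100 nM
Compound 3 `COc1ccc(/C=C/C(=O)c2ccc(OC)c3c2OC(C)(C)C=C3)cc1OC(=O)C(C)C`: 310 nM

In a functional assay on A-375 cells (Homo sapiens) for cytotoxicity, read by MTT assay (a higher number here means a weaker inhibitor, a lower number a stronger inhibitor), compound 3 has the lowest of these three numbers. The measured steps to it are a 2.6-fold lower number from compound 1 to compound 3 (0.41 log units; beyond the scatter) and a 13-fold lower number from compound 2 to compound 3 (1.12 log units; beyond the scatter). Compound 4 `C=CC(=O)Oc1cc(/C=C/C(=O)c2ccc(OC)c3c2OC(C)(C)C=C3)ccc1OC` differs from compound 3 only within the acyl group: vinyl in place of isopropyl on a carbonyl carbon. Among the measured compounds shown here, no measured step exchanges one such group for another, so both steps bear on it only indirectly. They show that isopropylcarbonyl gives a lower number than hydrogen or 3-(dimethylamino)propyl on that oxygen. Vinylcarbonyl is expected to behave similarly, with no shift beyond the scatter. The expected change is a 1.1-fold lower number from compound 3 to compound 4 (0.04 log units; within the scatter). For compound 4 the estimated value is 280 nM, with an expected range of 110 nM to 700 nM.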

Compound 4, half-maximal inhibitory concentration: 390 nM
Compound 4: the middle estimate sits 1.4-fold (0.14 log units) below what was measured; low and high end bracket the measured number.
By their numbers in this assay, from the lowest: compounds 3 and 4 (each within the scatter of the next); then compound 1; then compound 2.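

In this assay, among the compounds shown here, vinyl in place of isopropyl on the carbonyl carbon gives a 1.3-fold higher number from compound 3 to compound 4 (0.10 log units; within the scatter) and so leaves the two acyl groups unseparated, a direct comparison the earlier compounds did not offer. Vinylcarbonyl on that oxygen also differs from hydrogen, with a 2.1-fold lower number from compound 1 to compound 4 (0.31 log units; beyond the scatter) and from 3-(dimethylamino)propyl, with an 11-fold lower number from compound 2 to compound 4 (1.02 log units; beyond the scatter) as the corresponding step. Nothing available explains these steps.

Going by these compounds, whether a longer acyl chain or a benzoyl group would fall in the same range remains open. So does whether an acyl group carrying an amine or a carboxylic acid would do so.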